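Sulfinyl in place of hydroxymethyl on the shared core

The source may report more compounds than this note shows. Statements on the series, on what has been measured and on what is new or still open speak of the compounds shown alone.

The series rests on the shared core of compound 1 `O=C(CC1CCN(Cc2ccccc2)CC1)c1ccc(C(F)(F)F)cc1`, a molecule that in an assay on isolated protein for binding affinity to Sigma non-opioid intracellular receptor 1 (Mus musculus) (a higher number here means a weaker inhibitor, a lower number a stronger inhibitor), gives 10 nM. Compound 2 `O=C(CC1CCN(Cc2ccccc2)CC1)c1ccc(CO)cc1` carries a hydroxymethyl where compound 1 has a trifluoromethyl, and in this assay compound 2 gives 31 nM. Among the two numbers known, compound 2 stands highest; the only measured step, a 3.1-fold higher number from compound 1 to compound 2 (0.49 log units; beyond the scatter), is modest but beyond the scatter.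

Compound 3 `C[S+]([O-])c1ccc(C(=O)CC2CCN(Cc3ccccc3)CC2)cc1` is the next variation on this position. Compared with compound 2 the change is a group of 3 heavy atoms (1 carbon, 1 oxygen, 1 sulfur; no ring) in place of a group of 2 heavy atoms (1 carbon, 1 oxygen; no ring), on an aromatic carbon. Among the measured compounds shown here, no measured step exchanges one group of this kind for another, so the only guidance is the step from compound 1 to compound 2, which shows that swapping the group at this position shifts the number by a modest amount. For compound 3 a step of about that size or smaller is expected, with no clear direction, most likely a small move toward a higher number, a 1.3-fold higher number from compound 2 to compound 3 (0.11 log units; within the scatter). Accordingly compound 3 is expected to give about 40 nM in this assay, in a range from 15 nM to 110 nM.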

Compound 3, inhibition constant: 53 nM
Beside the measured number, compound 3's estimate is 1.3-fold (0.12 log units) below it; the measured number falls inside the stated range.
By their numbers in this assay, from the lowest: compound 1; then compounds 2 and 3 (each within the scatter of the next).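

In this assay the exchange of hydroxymethyl for the sulfinyl group gives a 1.7-fold higher number from compound 2 to compound 3 (0.23 log units; within the scatter) and so does not separate the two groups at this position, even though the entering group has 0 hydrogen-bond donors and the leaving group has 1. Set against trifluoromethyl, the same group gives a 5.3-fold higher number from compound 1 to compound 3 (0.72 log units; beyond the scatter) and thus joins hydroxymethyl as a second replacement whose step from compound 1 lies beyond the scatter, so compound 1 now stands apart from both compound 2 and compound 3. Nothing available here accounts for these numbers.

The compounds shown leave open whether an amine, a carboxylic acid or a nitrile on this aromatic carbon would give a number close to those of compound 2 and compound 3 or one closer to that of compound 1. They also leave open whether a simple chlorine or a longer chain would fall with trifluoromethyl or with the other two groups, and whether the gap seen here would persist with a change elsewhere on the shared core.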